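The compounds below may be only part of what the source reports. "The series", "measured", "known", "first", "only" and "open" are said of these compounds alone.

Measured compounds:
compound 1, `Cc1cc2c(c(N)nn2C)c(N2CCCCC2)n1`, 7%
compound 2, `Cc1cc2c(c(N)nn2C)c(N2CC[C@H](O)C2)n1`, 2%

In an assay on isolated protein for inhibition of MAP kinase-activated protein kinase 2 (Homo sapiens), read by mobility shift assay, tested at 30 uM (on this read-out lower numbers stand for less inhibition and higher numbers for more inhibition at the one concentration tested (going by the name of the read-out)), compound 1 gives 7%, and in this assay compound 2 gives 2%. Compound 2 stands lowest of the two numbers, and compound 1 is the nearest to it. Going by the values given here, the one measured step, a number 5 percentage points lower from compound 1 to compound 2 (within the scatter), put 3-hydroxypyrrolidin-1-yl in place of piperidin-1-yl on an aromatic carbon and stayed within the scatter, so neither compound shows much inhibition at this concentration.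

Compound 3, `COCCNc1nc(C)cc2c1c(N)nn2C`, has not been measured. Its change from compound 2 is (2-methoxyethyl)amino in place of 3-hydroxypyrrolidin-1-yl on an aromatic carbon. The step from compound 1 to compound 2 is the only one that bears on it, as it also swapped the amine group on that same aromatic carbon, and it was small. Both measured numbers are low, so no step beyond the scatter is expected in this assay. For compound 3 a value of 5% is expected, between 0% and 20%. The expected step is a number 3 percentage points higher from compound 2 to compound 3 (within the scatter), within the scatter.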

Compound 3, a percentage reported as inhibition, at one concentration (the size of the read-out at that concentration, not a potency): 6%
The estimate for compound 3 lay 1 percentage points below the measured number; the measured number falls inside the stated range.
By their numbers in this assay, from the lowest: compounds 2, 3 and 1 (each within the scatter of the next).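

In this assay, putting (2-methoxyethyl)amino on this aromatic carbon next to the ring nitrogen gives a number 4 percentage points higher from compound 2 to compound 3 (within the scatter), and set against the piperidine it gives a number 1 percentage points lower from compound 1 to compound 3 (within the scatter). An entering group with no ring therefore reads the same, within the scatter, as the five-membered and six-membered ring amines, so among these three compounds a ring at this place makes no visible difference at the one concentration tested. Nothing on hand explains why these three groups read alike.

From the compounds shown here alone, all three numbers are low, so it remains open whether any group at this place can lift inhibition clearly, for example a phenyl ring, a carboxylic acid or a longer chain ending in a primary amine. Going by these compounds, whether a change elsewhere on the shared core, such as at the methyl group, would matter more also remains unknown.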